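Chain extension on the aryl ether of compound 3

The source may report more compounds than this note shows. Statements on the series, on what has been measured and on what is new or still open speak of the compounds shown alone.

Measured compounds:
compound 1, `C=CCc1cc(C(C)=O)c(O)cc1OCC#N`, 2%
compound 2, `CCc1cc(C(C)=O)c(O)cc1OCCCC(C)(C)C(N)=O`, 51%
compound 3, `C=CCc1cc(C(C)=O)c(O)cc1OCCCC`, 8%

In an assay on isolated protein for binding affinity to leukotriene B4 receptor 1 (Homo sapiens), tested at 1 uM (on this read-out lower numbers stand for less inhibition and higher numbers for more inhibition at the one concentration tested (going by the name of the read-out)), compound 3 gives 8%, the second highest of the three numbers; its nearest neighbour is compound 1, whose value lies within the scatter, while compound 2 sits well beyond the scatter above it. Among the compounds with values here, the one measured step on a single change, a number 6 percentage points higher from compound 1 to compound 3 (within the scatter), is within the scatter and concerns a different part of the chain than the change now in question, so it gives little direct guidance. Compound 2 shares no single-change relation with compound 3, but its value shows that a longer chain on the aryl oxygen carrying a polar end can go with a markedly higher number.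

Compound 4, `C=CCc1cc(C(C)=O)c(O)cc1OCCCCCC(=O)OC`, differs from compound 3 by (methoxycarbonyl)methyl in place of hydrogen on a saturated chain carbon, four bonds along the chain from an oxygen on an aromatic ring. The closest guide is the pair of values of compound 2 and compound 3, read with caution since they differ in two places. For this assay the step of a number 14 percentage points higher from compound 3 to compound 4 (beyond the scatter) is expected to be upward but modest, and compound 4 is estimated at 22%, within the range 4% to 48%.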

Compound 4, a percentage reported as inhibition, at one concentration (the size of the read-out at that concentration, not a potency): 65%
Estimate against measurement, compound 4: 43 percentage points below; the measured number lies above the stated range.
By their numbers in this assay, from the lowest: compounds 1 and 3 (each within the scatter of the next); then compound 2; then compound 4.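

In this assay the change from hydrogen to (methoxycarbonyl)methyl on a saturated chain carbon, four bonds along the chain from an oxygen on an aromatic ring, gives a number 57 percentage points higher from compound 3 to compound 4 (beyond the scatter). Within the data shown here, this is the first single change on this ether chain to move the number beyond the scatter, whereas the earlier step, a number 6 percentage points higher from compound 1 to compound 3 (within the scatter), showed no readable shift; the outer part of the chain is therefore a place where the read-out can respond strongly on the shared core. No measurement at hand gives a reason for this rise.

The step adds chain length and a methyl ester together, so a plain longer alkyl chain with no ester would be needed to separate the two contributions, and a carboxylic acid or primary amide at the same chain end would show whether the methyl ester itself matters. Also open, from the compounds shown here alone, is whether a shorter chain carrying the same methyl ester keeps the higher number, or whether a still longer chain raises it further.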